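The compounds below may be only part of what the source reports. "The series", "measured", "known", "first", "only" and "open" are said of these compounds alone.

Measured so far in a functional assay on HCT-116 cells (Homo sapiens) for antiproliferative activity, read by MTT assay, with a stated time of 72 h; a lower number here means a stronger inhibitor, a higher number a weaker inhibitor:
compound 1 `C=CC(=O)Nc1nc(-c2ccccc2Cl)cs1`, 12300 nM
compound 2 `C=CC(=O)Nc1nc(-c2ccccc2F)cs1`, 20400 nM
compound 3 `C=CC(=O)N(Cc1cc(C)no1)c1nc(-c2ccc(Cl)cc2O)cs1`, a limit only, > 30000 nM

Compound 1 and compound 2 share a core, and the change between them is fluoro in place of chloro on an aromatic carbon. It gives a 1.7-fold higher number from compound 1 to compound 2 (0.22 log units; within the scatter). Compound 3 carries a different core; the difference between the core of compound 1 and that of compound 3 is not broken down here. For compound 3 this assay reports no number, only (the limit of > 30000 nM in this assay, at which 1 of the 3 values shown sits).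

Compound 4 `C=CC(=O)N(Cc1cc(C)no1)c1nc(-c2ccc(F)cc2O)cs1` is not yet measured. Relative to compound 3 the change is fluoro in place of chloro on an aromatic carbon. Among the measured compounds shown here, this is the same kind of change as the one from compound 1 to compound 2, but the surroundings differ: in compound 1 the chloro sits ortho to a large group, whereas in compound 3 it sits meta to a hydroxy group (1 heavy atom) and para to a large group. The expected step is a step that the limit leaves unreadable from compound 3 to compound 4, resting on the measured 1.7-fold higher number from compound 1 to compound 2 (0.22 log units; within the scatter), which was within the scatter. Since compound 3 reached only the limit, compound 4 is expected to give 40000 nM, most likely again as a limit.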

Compound 4, half-maximal inhibitory concentration: > 30000 nM
Compound 4 gave a limit, no number; the forecaster's own chance of this, stated with the estimate: 80%; the middle value is on the limit's open side.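

In this assay, compound 3 and compound 4 are both reported only as limits, so no step can be read between them: the limit of > 30000 nM in this assay, at which 2 of the 4 values shown sit.

Left open is whether fluoro in place of chloro makes any difference on the core shared by compound 3 and compound 4, and how far either compound lies past the limit.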